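Methoxy removal on the benzoyl ring of compound 1

The source may hold more compounds than are shown below. What is called first, only, known or untested is meant among the compounds shown, and "the series" means these compounds.

Measured so far:
compound 1 `COc1ccc(C(=O)c2sc(Nc3ccccc3)nc2N)cc1OC`: 6900 nM
compound 2 `COc1ccc(Nc2nc(N)c(C(=O)c3ccc(OC)c(OC)c3)s2)cc1`: 10 nM

In a functional assay on CCRF-CEM cells (Homo sapiens) for antiproliferative activity, read by cell counting, with a stated time of 2 days (a lower number here means a stronger inhibitor, a higher number a weaker inhibitor), compound 1 gives the higher of the two numbers; the nearer neighbour is compound 2, reached by a 690-fold lower number from compound 1 to compound 2 (2.84 log units; beyond the scatter). Compound 3 `COc1cccc(C(=O)c2sc(Nc3ccccc3)nc2N)c1` differs from compound 1 by hydrogen in place of methoxy on an aromatic carbon. Going by the values given here, the only measured step concerns a methoxy entering on the other ring, so it bears on this change only loosely; it shows that a methoxy can matter greatly. For compound 3 a step of a 1.7-fold higher number from compound 1 to compound 3 (0.24 log units; within the scatter) is expected, toward a higher number, though the direction is uncertain. Compound 3 is estimated at 12000 nM, range 4000 nM to 40000 nM.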

Compound 3, half-maximal inhibitory concentration: 2300 nM
Beside the measured number, compound 3's estimate is 5.2-fold (0.72 log units) above it, and the stated range ends above it.
By their numbers in this assay, from the lowest: compound 2; then compound 3; then compound 1.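

In this assay hydrogen in place of methoxy, on an aromatic carbon ortho to a methoxy group and para to a large group, gives a 3.0-fold lower number from compound 1 to compound 3 (0.48 log units; beyond the scatter) beyond the scatter, so this methoxy is not required for activity on the core of compound 1. Losing a methoxy here lowers the number modestly, while a 690-fold lower number from compound 1 to compound 2 (2.84 log units; beyond the scatter) shows a much larger drop when a methoxy is added elsewhere. Nothing on hand explains the new step.

Still open, on these data alone, is whether a hydroxyl or an amine on this carbon would shift the number in the same direction. Also open, as far as these compounds go, is whether the same step holds with the added methoxy of compound 2 present.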